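The compounds below may be only part of what the source reports. "The series", "measured", "known", "first", "only" and "open" are said of these compounds alone.

Working notes on the series in a functional assay on the whole organism (Peritoneal cavity) with Rattus norvegicus as the target; a lower number here means that less compound is needed, a higher number that more compound is needed for the effect. Compound 1 `CC(C)(/C=N/OCC(=O)O)Cc1c(SC(C)(C)C)c2cc(OCc3ccc4ccccc4n3)ccc2n1Cc1ccc(Cl)cc1` gives 0.24 umol/kg, compound 3 `CC(C)(/C=N/OCC(=O)O)Cc1c(SC(C)(C)C)c2cc(OCc3cccc(Cl)n3)ccc2n1Cc1ccc(Cl)cc1` gives 2.6 umol/kg, and compound 2 `CC(C)c1ccc2c(c1)c(SC(C)(C)C)c(CC(C)(C)CNC(N)=O)n2Cc1ccc(Cl)cc1` gives 11 umol/kg. Compound 3 thus holds the middle of the three numbers, with compound 2 the nearer neighbour and compound 1 the further one.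

The next change leads from compound 3 to compound 4 `CC(C)(/C=N/OCC(=O)O)Cc1c(SC(C)(C)C)c2cc(OCc3cscn3)ccc2n1Cc1ccc(Cl)cc1`: 1,3-thiazol-4-yl in place of 6-chloropyridin-2-yl on a saturated chain carbon bound to an oxygen on an aromatic ring, (1,3-thiazol-4-yl in place of 6-chloropyridin-2-yl on a saturated chain carbon bound to an oxygen on an aromatic ring).

Among the measured compounds shown here, one measured step bears on this place: an 11-fold higher number from compound 1 to compound 3 (1.03 log units; beyond the scatter), with 6-chloropyridin-2-yl in place of quinolin-2-yl. It shows that a swap here can move the number by a large amount, but it is a single step and does not involve 1,3-thiazol-4-yl. For the measured compounds named here, no measured compound carries that group, so the data set no direction.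

The working expectation is therefore that the number stays near that of compound 3 at 2.6 umol/kg, with a wide range on either side. The expected step is a 1.3-fold lower number from compound 3 to compound 4 (0.11 log units; within the scatter), which would not clearly exceed the scatter. For compound 4 the estimate is 2 umol/kg, with an expected range from 0.5 umol/kg to 8 umol/kg.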

Compound 4, dose for half-maximal effect: 4.4 umol/kg
For compound 4 the middle estimate is 2.2-fold (0.34 log units) below the measured one; measured number inside the range.
By their numbers in this assay, from the lowest: compound 1; then compounds 3 and 4 (each within the scatter of the next); then compound 2.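

In this assay, replacing 6-chloropyridin-2-yl with 1,3-thiazol-4-yl on a saturated chain carbon bound to an oxygen on an aromatic ring gives a 1.7-fold higher number from compound 3 to compound 4 (0.23 log units; within the scatter), so a five-membered aromatic ring with 2 hetero atoms and the chlorine-bearing six-membered ring cannot be told apart at this place. The step from quinolin-2-yl to 1,3-thiazol-4-yl is an 18-fold higher number from compound 1 to compound 4 (1.26 log units; beyond the scatter), which matches in kind the large step of an 11-fold higher number from compound 1 to compound 3 (1.03 log units; beyond the scatter), and among these three groups only quinolin-2-yl gives the low number, with no compound here going against that. Nothing at hand accounts for the separation of quinolin-2-yl from the other two groups or for the closeness of those two.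

The compounds shown leave open how a plain phenyl, an unsubstituted pyridin-2-yl or an isoquinolin-3-yl group would stand at this place, and so whether the low number of compound 1 belongs to quinolin-2-yl alone. They also leave open whether these swaps would move the number in the same way on the core of compound 2.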